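This account rests on a few compounds, and the source may have more. Where it says the series, first, only, none or still open, it means among the compounds named here.

Compound 1 `CNc1nc(C#N)nc(NC2(C#N)CCCCC2)n1` is the reference point. In an ADME assay on microsomes from liver (Rattus norvegicus) for metabolic stability (a higher number here means faster removal of the compound, a lower number slower removal), compound 1 gives 122 mL/min/kg, the highest of the three numbers in hand; compound 2 `CCCC(C#N)(CCC)Nc1nc(NC)nc(-n2cncn2)n1` gives 32 mL/min/kg and compound 3 `CCCC(C#N)(CC)Nc1nc(NC)nc(-n2cncn2)n1` gives 29 mL/min/kg, both lying beyond the scatter below compound 1. Among the compounds with values here, the only measured step, a 1.1-fold lower number from compound 2 to compound 3 (0.04 log units; within the scatter), concerns a saturated chain and not the aromatic carbon changed here, so it does not bear on the present step. Compound 4 `CNc1nc(NC2(C#N)CCCCC2)nc(-n2cccn2)n1` differs from compound 1 by 1H-pyrazol-1-yl in place of cyano on an aromatic carbon. Compounds 2 and 3 each differ from compound 1 in two places, so what their lower numbers say of this change alone is uncertain. A modest downward step is expected, a 1.7-fold lower number from compound 1 to compound 4 (0.24 log units; within the scatter). Compound 4 is therefore expected to give 70 mL/min/kg in this assay, within 30 mL/min/kg to 160 mL/min/kg.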

Compound 4, clearance: 103 mL/min/kg
Compound 4: middle estimate off by 1.5-fold (0.17 log units), on the low side; measured number inside the range.
By their numbers in this assay, from the lowest: compounds 3 and 2 (each within the scatter of the next); then compounds 4 and 1 (each within the scatter of the next).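

In this assay, 1H-pyrazol-1-yl in place of cyano on the aromatic carbon opposite the ring nitrogen gives a 1.2-fold lower number from compound 1 to compound 4 (0.07 log units; within the scatter). At this position, then, a five-membered aromatic ring can stand where the nitrile stood with no step beyond the scatter, which compounds 2 and 3, each differing from compound 1 in two places, could not show. No measurement in hand accounts for this result.

As far as these compounds go, whether an amine or a carboxylic acid on this aromatic carbon would give a step beyond the scatter remains open. Also open, from the compounds shown here alone, is which of the two places carries the lower numbers of compounds 2 and 3.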